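The compounds below may be only part of what the source reports. "The series", "measured", "known", "first", "only" and "open" are said of these compounds alone.

Working notes on the series, read in a functional assay on HOP-92 cells (Homo sapiens) for inhibition, read by sulforhodamine B assay, with a stated time of 48 h; on this read-out higher numbers stand for weaker inhibition of growth and lower numbers for stronger inhibition of growth. Compound 1 `O=C(Nc1cccc(-n2cc(-c3ccncc3)c(-c3ccc(Cl)c(O)c3)n2)c1)Nc1cccc(C(F)(F)F)c1` gives 2230 nM, which lies within the scatter of both compound 2 `COc1cc(-c2nn(-c3cccc(NC(=O)c4cccc(C(F)(F)F)c4)c3)cc2-c2ccncc2)ccc1Cl` at 3120 nM and compound 3 `COc1cc(-c2nn(-c3cccc(NC(=O)Nc4ccc(Cl)c(Cl)c4)c3)cc2-c2ccncc2)ccc1Cl` at 1470 nM. No order can be claimed between compound 1 and either of these.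

Compound 4 `COc1cc(-c2nn(-c3cccc(NC(=O)Nc4cccc(C(F)(F)F)c4)c3)cc2-c2ccncc2)ccc1Cl` differs from compound 1 in one place: methyl in place of hydrogen on an oxygen on an aromatic ring, or hydroxy to methoxy. Going by the values given here, no measured pair isolates this change. Among the compounds with values here, the only measured step, a 2.1-fold lower number from compound 2 to compound 3 (0.33 log units; beyond the scatter), is modest and lies between two methoxy compounds, so it bears on the change only indirectly. Compound 4 keeps the 3-(trifluoromethyl)phenyl of compound 2 and compound 1, and its closest methoxy comparators sit close to compound 1 in this assay. No shift beyond the scatter is therefore expected, and no direction can be argued from these data.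

An estimated step of a 1.1-fold lower number from compound 1 to compound 4 (0.03 log units; within the scatter) is expected. For compound 4 the expected value is 2100 nM, with an estimated range of 1000 nM to 4300 nM.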

Compound 4, concentration for total growth inhibition: 1770 nM
Beside the measured number, compound 4's estimate is 1.2-fold (0.07 log units) above it, within the range that was stated.
By their numbers in this assay, from the lowest: compounds 3, 4, 1 and 2 (each within the scatter of the next, the first and the last beyond it).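

In this assay the change from hydroxy to methoxy now has a direct pair, and a 1.3-fold lower number from compound 1 to compound 4 (0.10 log units; within the scatter) shows that methyl in place of hydrogen on this oxygen leaves the number within the scatter. Compound 4 also splits the earlier gap between compound 2 and compound 3 into two single changes, neither beyond the scatter: a 1.8-fold lower number from compound 2 to compound 4 (0.25 log units; within the scatter) for (3-(trifluoromethyl)phenyl)amino in place of 3-(trifluoromethyl)phenyl on a carbonyl carbon, and a 1.2-fold higher number from compound 3 to compound 4 (0.08 log units; within the scatter) for 3-(trifluoromethyl)phenyl in place of 3,4-dichlorophenyl on an amide-type nitrogen. No supporting data accompany these numbers to account for the result.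

Going by these compounds, the hydroxy to methoxy change rests on a single pair, so its outcome alongside the 3,4-dichlorophenyl of compound 3 remains open. Also open, on these data alone, is whether a longer chain on this oxygen, such as ethoxy, or an amine in place of the hydroxy, would stay within the scatter.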